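The compounds below may be only part of what the source reports. "The series", "measured", "known", "first", "only" and "open" are said of these compounds alone.

Compound 1 `COc1ccc(/C=C/C2CC=CC(=O)O2)cc1OC` and compound 2 `COc1cc(OC)c(OC)cc1/C=C/C1CC=CC(=O)O1` share one core and differ by methoxy in place of hydrogen on an aromatic carbon. In an ADME assay on HaCaT cells (Homo sapiens) for inhibition, read by sulforhodamine B assay, with a stated time of 48 h (a lower number here means a stronger inhibitor of growth, a higher number a weaker inhibitor of growth), compound 1 gives 63 uM. In this assay compound 2 gives 46.9 uM, a step of a 1.3-fold lower number from compound 1 to compound 2 (0.13 log units; within the scatter). Compound 3 `COc1ccc(/C=C/C2CC=CC(=O)N2)cc1` carries another core; the difference between the two cores is not broken down here. In this assay compound 3 reaches only a limit, > 1090 uM. Compound 4 `COc1ccc(/C=C/C2CC=CC(=O)N2)c(OC)c1` follows from compound 3 by methoxy in place of hydrogen on an aromatic carbon. This is the same kind of change as before, though the place is not identical: in compound 2 the entering methoxy is also para to a methoxy group, which is not so in compound 4. Expected here is a step that the limit leaves unreadable from compound 3 to compound 4, a small step, because the same change gave a 1.3-fold lower number from compound 1 to compound 2 (0.13 log units; within the scatter). Compound 4 is therefore expected again to show only a limit in this assay. Compound 4 is estimated at 1500 uM, between 500 uM and 5000 uM.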

Compound 4, concentration for growth inhibition (reported as GI): > 964 uM
Compound 4: a limit, no number; the forecaster's own chance of this, stated with the estimate: 75%; the middle value is on the limit's open side.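

In this assay, for the compounds shown here, compound 3 and compound 4 both stand only as limits, and no step between them can be read. Left open is what methoxy in place of hydrogen on an aromatic carbon does to growth inhibition on the core of compound 3.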